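The source may hold more compounds than are shown below. What is called first, only, known or untested is meant among the compounds shown, and "the series" means these compounds.

Measured in a functional assay on HL-60 cells (Homo sapiens) for cytotoxicity, read by ELISA, with a stated time of 2 days; on this read-out higher numbers stand for weaker inhibition and lower numbers for stronger inhibition:

- Compound 1 `Oc1cccc(-c2cc(-c3ccccc3)cc(-c3cccs3)n2)c1`: 14100 nM
- Compound 2 `Oc1ccc(-c2cc(-c3ccccc3)cc(-c3ccccc3)n2)cc1`: 1400 nM

Among the compounds with values here, compound 2 holds the lower of the only two numbers, at 1400 nM, so it is the stronger inhibitor here. Compound 1 gives 14100 nM, a gap well beyond the usual scatter. These two compounds differ in more than one place, so their gap cannot be pinned on any single change.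

The next compound, compound 3 `Oc1ccc(-c2cc(-c3ccccc3)cc(-c3cccs3)n2)cc1`, keeps the 4-hydroxyphenyl group of compound 2 but has thiophen-2-yl in place of phenyl on an aromatic carbon. It thus shares thiophen-2-yl with compound 1. Within the data shown here, no measured pair shows this exchange alone, so the expectation in this assay is only tentative. Among the measured compounds shown here, the one hint is that compound 1, which also carries thiophen-2-yl, gives 14100 nM. A modest move toward a higher number, meaning weaker inhibition, is therefore expected, near the edge of the scatter. The expected step of a 2.1-fold higher number from compound 2 to compound 3 (0.33 log units; beyond the scatter) is small. For compound 3 the estimated value is 3000 nM, with an expected range from 900 nM to 11000 nM.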

Compound 3, half-maximal inhibitory concentration: 1700 nM
Compound 3: the middle estimate sits 1.8-fold (0.25 log units) above what was measured, and the stated range covers the measured number.
By their numbers in this assay, from the lowest: compounds 2 and 3 (each within the scatter of the next); then compound 1.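

In this assay, thiophen-2-yl in place of phenyl on the aromatic carbon next to the ring nitrogen gives a 1.2-fold higher number from compound 2 to compound 3 (0.08 log units; within the scatter), so the two rings cannot be told apart at this position, even though one has five ring atoms, including a sulfur, and the other has six carbons. Compound 3 also forms a single-change pair with compound 1, which the first two compounds could not do: 4-hydroxyphenyl in place of 3-hydroxyphenyl gives an 8.3-fold lower number from compound 1 to compound 3 (0.92 log units; beyond the scatter), so with thiophen-2-yl held constant, where the hydroxyl group sits on that ring matters far more here than the ring exchange does. No measurement on hand speaks to the reason for either step.

From the compounds shown here alone, whether this position accepts anything other than an aromatic ring stays open, since an amine, a methoxy group or a longer alkyl chain there could behave quite differently from phenyl and thiophen-2-yl. Going by these compounds, it is equally open whether the hydroxyl group itself is needed, which a methoxy group or an amine in its place on the 4-hydroxyphenyl ring would test.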